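This account rests on a few compounds, and the source may have more. Where it says the series, first, only, none or still open, it means among the compounds named here.

Compound 1 `CCN(CC)c1cc2[nH]c(C3CCCCC3)nc2cc1NC(=O)OCC(F)(F)F` gives > 100 ug/mL in an ADME assay on Vero cells (Chlorocebus sabaeus) for cytotoxicity, read by resazurin assay, with a stated time of 3 days (on this read-out lower numbers stand for stronger inhibition and higher numbers for weaker inhibition), which is a limit of the assay rather than a number.
Compound 2 `CN(C)c1cc2[nH]c(C3CCCCC3)nc2cc1NC(=O)OCc1ccccc1` gives > 100 ug/mL in this assay, again a limit.
Compound 3 `CCCN(CCC)c1cc2[nH]c(C3CCCCC3)nc2cc1NC(=O)OCc1ccccc1` gives > 100 ug/mL in this assay, again a limit.

Compound 2 therefore stands at the top of what this assay can report, with no number of its own, and the two other values shown stand at the same limit (the limit of > 100 ug/mL in this assay, at which 3 of the 3 values shown sit). Going by the values given here, the only single-site step among the measured compounds, a step that the two limits leave unreadable from compound 2 to compound 3, joins two limits and so tells nothing about size or direction.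

Compound 4 `CN(C)c1cc2[nH]c(C3CCCCC3)nc2cc1NC(=O)c1ccco1` differs from compound 2 in one place: furan-2-yl in place of benzyloxy on a carbonyl carbon. Among the compounds with values here, none of the measured steps touches the carbonyl carbon, so no measured step bears on this change, and the three limits give no readable step of any size to build on. Within the data shown here, every compound measured so far sits at the limit (the limit of > 100 ug/mL in this assay, at which 3 of the 3 values shown sit), which is the only guide available.

Compound 4 is therefore expected to sit at or near the same limit, estimated at 100 ug/mL with a range from 50 ug/mL to 200 ug/mL. The step from compound 2 is expected to be a number no higher from compound 2 to compound 4 (the limit leaves the size open), that is, none beyond the usual scatter.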

Compound 4, half-maximal inhibitory concentration: > 100 ug/mL
Compound 4: only a limit was reported (the forecaster's own chance of this, stated with the estimate: 80%); the middle value lies on the limit itself.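

In this assay compound 4 gives > 100 ug/mL, which is a limit and not a number. Compound 2 also sits at a limit, so no step can be read for furan-2-yl in place of benzyloxy. The compounds shown leave open how their true values compare, and what change would bring a measurable number, as all rest at one ceiling: the limit of > 100 ug/mL in this assay, at which 4 of the 4 values shown sit.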